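The source may hold more compounds than are shown below. What is called first, only, known or untested is meant among the compounds shown, and "the series" means these compounds.

The two measured compounds and their values in a functional assay on SK-MEL-28 cells (Homo sapiens) for inhibition, read by sulforhodamine B assay, with a stated time of 48 h; on this read-out higher numbers stand for weaker inhibition of growth and lower numbers for stronger inhibition of growth:

compound 1 `N=C(N)c1ccc(-c2ccc(-c3cncc4ccccc34)s2)s1`: 1640 nM
compound 2 `N=C(N)c1ccc(-c2ccc(-c3ccc(F)cc3)o2)o1`: 1630 nM

Compound 2 gives a number that sits within the usual scatter of the number given by compound 1, so on these two values neither compound can be set apart from the other; compound 2 simply shares the same level of growth inhibition with compound 1 in this assay.

Compound 3 `N=C(N)c1ccc(-c2ccc(-c3ccc(Cl)cc3)o2)o1` differs from compound 2 in one place: chloro in place of fluoro on an aromatic carbon. Going by the values given here, no step between two measured compounds covers such an exchange, so there is no measured precedent to lean on. A single halogen for another at the same position is expected to move the number little, if at all, beyond the scatter, with perhaps a slight lean toward stronger growth inhibition. The step from compound 2 to compound 3 is therefore estimated as a 1.4-fold lower number from compound 2 to compound 3 (0.13 log units; within the scatter). Compound 3 is expected to give 1200 nM in this assay, within a range from 400 nM to 3600 nM.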

Compound 3, concentration for 50% growth inhibition: 1830 nM
Estimate against measurement, compound 3: 1.5-fold (0.18 log units) below, and the stated range covers the measured number.
By their numbers in this assay, from the lowest: compounds 2, 1 and 3 (each within the scatter of the next).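

With chloro in place of fluoro on an aromatic carbon para to a large group, the step in this assay is a 1.1-fold higher number from compound 2 to compound 3 (0.05 log units; within the scatter) and so gives the first measured sign that, on this core, the two halogens at this position cannot be told apart. The earlier compounds shown here could not show this, as compound 1 and compound 2 differ in more than one place and offered no step at all. Nothing available offers an account of why the exchange leaves the reading within the scatter.

From the compounds shown here alone, whether an amine, a methoxy group or a carboxylic acid at this position, or a plain hydrogen there, would take the number beyond the scatter remains open. Also open, going by these compounds, is whether the same halogen exchange would read alike on a different core.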